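This account rests on a few compounds, and the source may have more. Where it says the series, first, only, none or still open, it means among the compounds named here.

Measured in an ADME assay on Vero cells (Chlorocebus sabaeus) for cytotoxicity, read by CCK-8 assay, with a stated time of 72 h; on this read-out higher numbers stand for weaker inhibition and lower numbers for stronger inhibition:
Compound 1 `Cc1ccn2nc(C)c(C(=O)NCc3ccc(N4CCC(c5ccc(OC(F)(F)F)cc5)CC4)cc3)c2c1` gives > 100000 nM, which is a limit of the assay rather than a number.
Compound 2 `COc1ccn2nc(C)c(C(=O)NCc3ccc(N4CCC(c5ccc(OC(F)(F)F)cc5)CC4)cc3)c2c1` gives > 100000 nM, again a limit.
Compound 3 `Cc1nn2ccccc2c1C(=O)NCc1ccc(N2CCC(c3ccc(OC(F)(F)F)cc3)CC2)cc1` gives > 100000 nM, also a limit.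

The three share one core and differ only in the group on a single aromatic carbon of that core. Compound 3 cannot be placed against the others: its value in this assay is a limit, and the two further values shown are limits too, so the limit of > 100000 nM in this assay, at which 3 of the 3 values shown sit, describes every measured compound. Accordingly the steps a step that the two limits leave unreadable from compound 1 to compound 3 and a step that the two limits leave unreadable from compound 2 to compound 3, and likewise a step that the two limits leave unreadable from compound 1 to compound 2, cannot be read in size or direction.

Compound 4 `CCc1ccn2nc(C)c(C(=O)NCc3ccc(N4CCC(c5ccc(OC(F)(F)F)cc5)CC4)cc3)c2c1` has not yet been measured. It differs from compound 3 by ethyl in place of hydrogen on an aromatic carbon. The closest measured comparisons are the methyl of compound 1 and the methoxy of compound 2 at the same carbon. Compound 1 in this assay gives > 100000 nM, a limit. Compound 2 gives > 100000 nM, a limit. On this basis the step is expected to be a number no higher from compound 3 to compound 4 (the limit leaves the size open), nothing beyond the scatter, with the result most probably reported as a limit once more. Compound 4 is therefore estimated at 100000 nM, with a range from 40000 nM to 300000 nM.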

Compound 4, half-maximal inhibitory concentration: > 100000 nM
Compound 4: a limit, no number (the forecaster's own chance of this, stated with the estimate: 85%); the middle value lies on the limit itself.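

The steps linking compound 4 to compound 1, compound 2 and compound 3 cannot be read in size or direction, because each compound sits at a limit of the assay rather than at a number: the limit of > 100000 nM in this assay, at which 4 of the 4 values shown sit.

Whether the group on this aromatic carbon changes the read-out at all remains open, as does the concentration at which any of these compounds would reach half-maximal inhibition.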